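Sulfanyl to aminoalkylamino on the shared core

The source may report more compounds than this note shows. Statements on the series, on what has been measured and on what is new or still open speak of the compounds shown alone.

Compound 1 `COCc1ncc2cnnc(SC)n12` is the reference. In a functional assay for inhibition, with Homo sapiens as the target (a higher number here means a weaker inhibitor, a lower number a stronger inhibitor), compound 1 gives > 48000 nM, which is a limit of the assay and not a number. Among the measured compounds shown here, compound 2 `CCc1nnc(S)n2c(C(C)CC)nc(C)c12` is the one other measured compound. In this assay compound 2 gives > 48000 nM, also a limit. Compound 1 therefore stands at the limit of > 48000 nM in this assay, at which 2 of the 2 values shown sit, with no measured position beyond it. Compound 3 `COCc1ncc2cnnc(NCCN(C)C)n12` carries (2-(dimethylamino)ethyl)amino in place of methylsulfanyl on an aromatic carbon. For the measured compounds named here, no measured step covers this change, so the estimate rests on the limit alone. The expected step is an at least 1.6-fold lower number from compound 1 to compound 3 (0.20 log units; that floor lies within the scatter), its direction not fixed by the data. Compound 3 is expected to give 30000 nM, between 4000 nM and 100000 nM.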

Compound 3, half-maximal inhibitory concentration: > 48000 nM
Compound 3: a limit, no number; the forecaster's own chance of this, stated with the estimate: 55%; middle value at least 1.6-fold (0.20 log units) from the limit.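

No step can be read from compound 1 to compound 3, since both values are limits and not numbers: the limit of > 48000 nM in this assay, at which 3 of the 3 values shown sit.

The compounds shown leave open whether (2-(dimethylamino)ethyl)amino in place of methylsulfanyl changes inhibition at all.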